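The source may hold more compounds than are shown below. What is called first, only, known or untested is meant among the compounds shown, and "the series" means these compounds.

Three compounds share one core and differ only in the amine at the end of the chain that hangs from the aromatic oxygen. Compound 1 `CCN(CC)CCCCOc1ccc(/C=C/C(=O)Nc2ccccc2)cc1OC` gives 1.59 in a physicochemical assay for lipophilicity, using the shake flask method, measured as octanol-water partition, at pH 7.4; on this read-out higher numbers stand for higher lipophilicity and lower numbers for lower lipophilicity. Compound 2 `COc1cc(/C=C/C(=O)Nc2ccccc2)ccc1OCCCCN1CCCC1` gives 1.6 in this assay, and compound 3 `COc1cc(/C=C/C(=O)Nc2ccccc2)ccc1OCCCCCN(C)C` gives 1.61. The three numbers sit close together: the step of a number 0.01 log units higher from compound 1 to compound 2 (within the scatter), the step of a number 0.02 log units higher from compound 1 to compound 3 (within the scatter) and the step of a number 0.01 log units higher from compound 2 to compound 3 (within the scatter) all fall within the scatter, so compound 3, although it shows the largest of the three numbers, cannot be set apart from the other two.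

Compound 4 `COc1cc(/C=C/C(=O)Nc2ccccc2)ccc1OCCCCCCCCN(C)C` keeps the dimethylamine of compound 3 but carries it on a longer chain: 3-(dimethylamino)propyl in place of dimethylamino on a saturated chain carbon, five bonds along the chain from an oxygen on an aromatic ring. Among the measured compounds shown here, none of the measured steps lengthens the chain; each swaps one amine for another of about the same size, and each stays within the scatter. They therefore give no direct measure of what a longer chain does, only the assurance that the amine itself hardly moved the number. For compound 4 the expected step is a number 1.29 log units higher from compound 3 to compound 4 (beyond the scatter), upward, beyond the scatter. The estimate for compound 4 in this assay is 2.9, with a range from 2.2 to 3.6.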

Compound 4, partition coefficient: 1.74
Beside the measured number, compound 4's estimate is 1.16 log units above it, outside the stated range (below it).
By their numbers in this assay, from the lowest: compounds 1, 2, 3 and 4 (each within the scatter of the next).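

Among the compounds shown here, the earlier compounds only swapped one amine for another of about the same size, so compound 4 gives the first direct reading of a longer chain at this position: 3-(dimethylamino)propyl in place of dimethylamino, on a saturated chain carbon, five bonds along the chain from an oxygen on an aromatic ring, gives a small step in this assay (a number 0.13 log units higher from compound 3 to compound 4 (within the scatter)). Set against the other two amines, compound 4 stands just as close (a number 0.14 log units higher from compound 2 to compound 4 (within the scatter); a number 0.15 log units higher from compound 1 to compound 4 (within the scatter)), so on this read-out the longer chain does not separate it from any of the three earlier compounds, and all four must be treated as indistinguishable. Nothing given here bears on what lies behind this result.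

On these data alone, it remains open whether an even longer chain ending in the same dimethylamine would carry the number clearly beyond the scatter, or whether this small step would hold there too. As far as these compounds go, it is equally open whether pyrrolidin-1-yl or diethylamino would behave like dimethylamino at the end of the longer chain, and how a carboxylic acid in place of the amine would read.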